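The source may hold more compounds than are shown below. What is called first, only, known or untested is meant among the compounds shown, and "the series" means these compounds.

In a functional assay on A549 cells (Homo sapiens) for antiproliferative activity, read by MTT assay, with a stated time of 48 h (on this read-out higher numbers stand for weaker inhibition and lower numbers for stronger inhibition), compound 1 (`CCN(CC)CCn1c(N)c(-c2nc3ccccc3[nH]2)c2nc(C#N)c(C#N)nc21`) gives > 50000 nM as a limit of the assay and not a number. Compound 3 (`CCN(CC)CCn1c(N)c(-c2nc3ccccc3n2C)c2nc(C#N)c(C#N)nc21`) likewise gives only a limit, > 50000 nM in this case, and so stands at the limit of > 50000 nM in this assay, at which 2 of the 3 values shown sit, with no number of its own. Compound 2 (`CCN(CC)CCCCn1c(N)c(-c2nc3ccccc3o2)c2nc(C#N)c(C#N)nc21`) gives a true number of 9390 nM and carries a 4-(diethylamino)butyl chain.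

Compound 4 (`CCN(CC)CCCCn1c(N)c(-c2nc3ccccc3n2C)c2nc(C#N)c(C#N)nc21`) differs from compound 3 in that chain alone: 2-(diethylamino)ethyl in place of diethylamino on a saturated chain carbon, two bonds along the chain from an aromatic nitrogen turns 2-(diethylamino)ethyl into 4-(diethylamino)butyl. For the measured compounds named here, the one measured step, a step that the two limits leave unreadable from compound 1 to compound 3 and does not touch the chain, so it gives no size to carry over. Going by the values given here, the only guide is compound 2 at 9390 nM. Compound 2 shares the longer chain with compound 4, although it differs from compound 4 elsewhere too. Stronger inhibition is therefore expected, with a wide margin, and the estimated change is an at least 3.3-fold lower number from compound 3 to compound 4 (0.52 log units; beyond the scatter) in that direction. For compound 4 the expected value is 15000 nM within an estimated range of 5000 nM to 50000 nM in this assay.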

Compound 4, half-maximal inhibitory concentration: 1720 nM
Compound 4: the middle estimate sits 8.7-fold (0.94 log units) above what was measured; the whole stated range lies above it.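

Replacing the 2-(diethylamino)ethyl chain with the 4-(diethylamino)butyl chain gives an at least 29-fold lower number from compound 3 to compound 4 (1.46 log units; beyond the scatter), the first readable size for this change, with 1-methyl-1H-benzimidazol-2-yl held constant. With the 4-(diethylamino)butyl chain held constant, 1-methyl-1H-benzimidazol-2-yl in place of 1,3-benzoxazol-2-yl gives a 5.5-fold lower number from compound 2 to compound 4 (0.74 log units; beyond the scatter), so the group on the aromatic carbon also shifts the result, although by less. Compound 1 and compound 3, which carry the shorter chain, each give only a limit of the assay and not a number: the limit of > 50000 nM in this assay, at which 2 of the 4 values shown sit.

The compounds shown leave open whether a chain longer than 4-(diethylamino)butyl would lower the number further, and whether a cyclic amine such as morpholine could replace diethylamino at the chain end. They also leave open how the 4-(diethylamino)butyl chain behaves with an unmethylated benzimidazole.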